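The compounds below may be only part of what the source reports. "The series", "measured", "known", "first", "only" and "open" are said of these compounds alone.

Measured in a physicochemical assay for metabolic stability, read by HPLC; on this read-out higher numbers stand for a longer-lived compound and lower numbers for a shorter-lived compound:
- compound 1 `Cc1ccc(OP(=O)(O)OC[C@H]2O[C@@H](n3cc(C)c(=O)[nH]c3=O)C[C@@H]2N=[N+]=[N-])cn1`: 28.9 h
- compound 2 `Cc1cn([C@H]2C[C@H](N=[N+]=[N-])[C@@H](COP(=O)(O)Oc3cccnc3)O2)c(=O)[nH]c1=O`: 3.88 h

Compound 2 holds the lower of the two numbers at 3.88 h. Compound 3 `Cc1cn([C@H]2C[C@H](N=[N+]=[N-])[C@@H](COP(=O)(O)Oc3ccc(Cl)cc3Cl)O2)c(=O)[nH]c1=O` carries 2,4-dichlorophenyl in place of pyridin-3-yl on an oxygen. For the measured compounds named here, the only measured step, a 7.4-fold lower number from compound 1 to compound 2 (0.87 log units; beyond the scatter), is modest and alters the group that now leaves. Going by the values given here, no measured compound carries chlorine, so the direction is weakly founded. In this assay a lower number is expected, by somewhat less than that measured step. The expected change is a 2.6-fold lower number from compound 2 to compound 3 (0.41 log units; beyond the scatter). The estimate for compound 3 is 1.5 h, with an expected range of 0.4 h to 6 h.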

Compound 3, half-life: 3.03 h
Estimate against measurement, compound 3: 2.0-fold (0.31 log units) below; the measured number falls inside the stated range.
By their numbers in this assay, from the lowest: compounds 3 and 2 (each within the scatter of the next); then compound 1.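

On the oxygen bound to phosphorus, this assay does not separate 2,4-dichlorophenyl from pyridin-3-yl, with a 1.3-fold lower number from compound 2 to compound 3 (0.11 log units; within the scatter) for this exchange. Against 6-methylpyridin-3-yl, the same group gives a 9.5-fold lower number from compound 1 to compound 3 (0.98 log units; beyond the scatter), so among these three groups only 6-methylpyridin-3-yl stands apart. No available evidence bears on why these numbers fall as they do.

From the compounds shown here alone, whether plain phenyl or a phenyl carrying one chlorine would read like 2,4-dichlorophenyl remains open. So does the reading for an alkyl chain on this oxygen in place of the aromatic ring.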